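The compounds below may be only part of what the source reports. "The series", "measured", "known", "first", "only" and "open" are said of these compounds alone.

Measured compounds:
compound 1, `O=C1c2ccccc2S(=O)(=O)N1CCCCCCN1CCN(c2cccc(Cl)c2Cl)CC1`: 119 nM
compound 2, `O=C1c2ccccc2S(=O)(=O)N1CCCCCCN1CCN(c2cccc(C(F)(F)F)c2)CC1`: 58 nM

In an ADME assay on HEK293 cells for displacement of a labelled ligand from 5-hydroxytryptamine receptor 7 (Homo sapiens), read by radioligand binding, with a stated time of 1 h (on this read-out lower numbers stand for stronger inhibition and higher numbers for weaker inhibition), compound 2 gives 58 nM, the lowest of the two numbers shown, and compound 1 gives 119 nM. Going by the values given here, the single measured step is a 2.1-fold lower number from compound 1 to compound 2 (0.31 log units; beyond the scatter). Compound 3 (`O=C1c2ccccc2S(=O)(=O)N1CCCCCCN1CCN(c2ccccc2)CC1`) differs from compound 2 by hydrogen in place of trifluoromethyl on an aromatic carbon. The measured step bears on the same aromatic ring attached to the amine nitrogen in a ring, but it exchanges one substituent pattern for another; it does not show what removing the trifluoromethyl altogether does. What it does show is that the group on that ring shifts the number only modestly. The step from compound 2 to compound 3 is therefore expected to be modest, if anything toward a higher number, a 2.1-fold higher number from compound 2 to compound 3 (0.32 log units; beyond the scatter). Compound 3 is expected at 120 nM, within 50 nM to 300 nM.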

Compound 3, inhibition constant: 192 nM
Compound 3: the middle estimate sits 1.6-fold (0.20 log units) below what was measured; measured number inside the range.
By their numbers in this assay, from the lowest: compound 2; then compounds 1 and 3 (each within the scatter of the next).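

In this assay, the trifluoromethyl group is now seen on its own: taking it off the aromatic ring gives a clear step (a 3.3-fold higher number from compound 2 to compound 3 (0.52 log units; beyond the scatter)), which the earlier exchange of one substituent pattern for another could not isolate. The phenyl and the 2,3-dichlorophenyl compounds, by contrast, cannot be told apart (a 1.6-fold higher number from compound 1 to compound 3 (0.21 log units; within the scatter)), so the effect of the ring substituent depends on which group is present and is not shared by these two patterns. Nothing available here accounts for this difference between the groups.

The compounds shown leave open whether a single chlorine, a methoxy or a nitrile on that aromatic carbon would behave like trifluoromethyl or like hydrogen. They also leave open how a shorter or longer chain would shift the number.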